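Fluoro step across two cores in a kinase inhibition screen

A few compounds are considered here, and "the series" means these few. Any claim that something is new, unique, unknown or untested is made for them only; others in the source may bear on it.

Compound 1 `c1ccc(Sc2ncnc3[nH]cnc23)cc1` and compound 2 `Fc1ccc(Sc2ncnc3[nH]cnc23)cc1` share one core; compound 3 `c1ccc(C[n+]2c[nH]c3ncncc32)cc1` and compound 4 `Fc1ccc(C[n+]2c[nH]c3ncncc32)cc1` share another, and the difference between the two cores is not broken down here. In an assay on isolated protein for inhibition of Ca2+/calmodulin-dependent protein kinase II (CaM kinase II) (Rattus norvegicus), tested at 30 uM (a higher number here means more inhibition at the concentration tested (going by the name of the read-out), a lower number less inhibition), compound 1 gives 0%, and compound 2 gives 0%. The change fluoro in place of hydrogen on an aromatic carbon thus made no change at the digits printed from compound 1 to compound 2 (within the scatter). Compound 3 gives 7% in this assay, which lies within the scatter of the values of compound 1 and compound 2, so no order among the three can be read. The change from compound 3 to compound 4 is fluoro in place of hydrogen on an aromatic carbon, the same change as from compound 1 to compound 2, at the same place on the ring. The earlier step was no change at the digits printed from compound 1 to compound 2 (within the scatter), and nothing among the three measured values suggests the second core behaves differently. For compound 4 the expected step is therefore a number 2 percentage points lower from compound 3 to compound 4 (within the scatter), resting on the flat earlier step. Compound 4 is estimated at 5% in this assay, with a likely range from 0% to 15%.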

Compound 4, a percentage reported as inhibition, at one concentration (the size of the read-out at that concentration, not a potency): 5%
Compound 4: middle estimate and measured number agree at the digits printed; the range from low to high includes it.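

In this assay the new step for fluoro in place of hydrogen on an aromatic carbon is a number 2 percentage points lower from compound 3 to compound 4 (within the scatter) and so stays as flat as the earlier one. The two steps do not differ, so on these two cores the change carries over: the same change on two cores in this assay, no change at the digits printed (within the scatter) from compound 1 to compound 2 and a number 2 percentage points lower (within the scatter) from compound 3 to compound 4, 2 percentage points apart, within the scatter of two such steps. This agreement is one between two flat steps only, from the starting numbers of compound 1 at 0% and compound 3 at 7% in this assay, and it does not show that the change would stay without effect on a compound with clear inhibition, at another concentration or in another assay.

Still open, from the compounds shown here alone, is whether a group other than fluoro at the same place on the ring, such as chloro, methoxy or a carboxylic acid, would move the number beyond the scatter. Also open, going by these compounds, is whether an amine on the ring, or a longer chain joining the ring to the core, would give any inhibition that stands clear of these low readings.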